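Benzothiazole-linked flavonol series: cytotoxicity notes on MDCK cells

The source may report more compounds than this note shows. Statements on the series, on what has been measured and on what is new or still open speak of the compounds shown alone.

Measured compounds, with the values found in an ADME assay on MDCK cells (Canis lupus familiaris) for cytotoxicity, read by sulforhodamine B assay, with a stated time of 48 h; on this read-out higher numbers stand for weaker inhibition and lower numbers for stronger inhibition:
Compound 1, `O=c1cc(-c2ccccc2)oc2cc(OCCCCNc3nc4ccccc4s3)cc(O)c12`: compound 1 gives 348 ug/mL.
Compound 2, `O=c1cc(-c2ccccc2)oc2cc(OCCCCNc3nc4ccc(I)cc4s3)cc(O)c12`: compound 2 gives 298 ug/mL.
Compound 3, `O=c1cc(-c2ccccc2)oc2cc(OCCCCNc3nc4ccc(C(F)(F)F)cc4s3)cc(O)c12`: compound 3 gives 278 ug/mL.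

All three numbers in this assay lie close together. Compound 2 stands second highest of the three; its nearest neighbour is compound 3, with a 1.1-fold lower number from compound 2 to compound 3 (0.03 log units; within the scatter), and its furthest is compound 1, with a 1.2-fold lower number from compound 1 to compound 2 (0.07 log units; within the scatter). Both of these steps, and also a 1.3-fold lower number from compound 1 to compound 3 (0.10 log units; within the scatter), fall within the scatter, so the substituent on the aromatic carbon of the benzothiazole has not moved the read-out in any direction that can be told from noise.

Compound 4, `O=c1cc(-c2ccccc2)oc2cc(OCCCCNNc3nc4ccccc4s3)cc(O)c12`, has not yet been measured. Relative to compound 2 the change is (1,3-benzothiazol-2-yl)amino in place of 6-iodo-1,3-benzothiazol-2-yl on an amine nitrogen. Among the compounds with values here, of the measured steps, only the iodo change seen in a 1.2-fold lower number from compound 1 to compound 2 (0.07 log units; within the scatter) bears on it, and that step was within the scatter; the insertion of the second nitrogen into the linker has no counterpart among the measured compounds. The expectation in this assay is therefore no step beyond the scatter, and the step from compound 2 to compound 4 is estimated as a 1.1-fold higher number from compound 2 to compound 4 (0.04 log units; within the scatter).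

Compound 4 is thus expected to give about 330 ug/mL, with a range from 170 ug/mL to 650 ug/mL.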

Compound 4, half-maximal inhibitory concentration: 316 ug/mL
The estimate for compound 4 lay 1.0-fold (0.02 log units) above the measured number; measured number inside the range.
By their numbers in this assay, from the lowest: compounds 3, 2, 4 and 1 (each within the scatter of the next).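

Within the data shown here, compound 4 gives the first reading of a change on the amine nitrogen whose other neighbour is a saturated chain carbon, since the earlier steps in this assay concerned only a substituent on an aromatic carbon of the benzothiazole. With (1,3-benzothiazol-2-yl)amino in place of 1,3-benzothiazol-2-yl on that nitrogen, the step reads a 1.1-fold lower number from compound 1 to compound 4 (0.04 log units; within the scatter), and with the same group in place of 6-iodo-1,3-benzothiazol-2-yl it reads a 1.1-fold higher number from compound 2 to compound 4 (0.03 log units; within the scatter). Neither step can be told from noise, so this position, for the one group entering here, joins the aromatic carbon as a place where the cytotoxicity read-out does not separate the compounds, and nothing shown here offers an explanation for how closely the numbers lie.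

Still open, going by these compounds, is whether a different kind of group on this amine nitrogen, such as a carboxylic acid, or a longer chain in place of the present linker, would give a step beyond the scatter. Also open, on these data alone, is whether an iodo or trifluoromethyl substituent on the benzothiazole of compound 4 would read any differently from compound 4 itself.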